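Compound 3: hydrogen replaces trifluoromethyl of compound 2

The source may report more compounds than this note shows. Statements on the series, on what has been measured and on what is new or still open speak of the compounds shown alone.

In an ADME assay on Vero cells (Chlorocebus sabaeus) for cytotoxicity, read by crystal violet staining (a higher number here means that more compound is tolerated, a lower number that less compound is tolerated), compound 1 `COc1ccc(/N=N/N2CCCC2)cc1` gives 90000 nM as its read-out. Compound 2 `FC(F)(F)c1cccc(/N=N/N2CCCC2)c1` stands at > 100000 nM and this is a limit of the assay, not a number. Compound 3 `c1ccc(/N=N/N2CCCC2)cc1` differs from compound 2 by hydrogen in place of trifluoromethyl on an aromatic carbon with hydrogen in place of trifluoromethyl on an aromatic carbon. Among the measured compounds shown here, no measured step covers this change. The estimated change an at least 1.0-fold lower number from compound 2 to compound 3 (0.02 log units; that floor lies within the scatter) is expected to stay within the scatter in either direction of this assay readings. For the measured compounds named here, that expectation rests on compound 1 with 90000 nM as the only numeric value. Compound 3 is expected at 95000 nM with 50000 nM to 180000 nM as the estimated range.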

Compound 3, half-maximal cytotoxic concentration: > 100000 nM
Compound 3 was reported as a limit (the forecaster's own chance of this, stated with the estimate: 50%); middle value at least 1.0-fold (0.02 log units) from the limit.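

In this assay compound 3 gives > 100000 nM, which is a limit and not a number, so trifluoromethyl is not required on this aromatic carbon for a reading at that limit. Hydrogen in place of methoxy gives an at least 1.1-fold higher number from compound 1 to compound 3 (0.04 log units; that floor lies within the scatter). The step between compound 2 and compound 3 cannot be read because both values are limits: the limit of > 100000 nM in this assay, at which 2 of the 3 values shown sit.

On these data alone, how far past the limit these compounds lie stays open. Also open, as far as these compounds go, is whether an amine or a carboxylic acid on this aromatic carbon would bring the reading down to a number.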